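The source may report more compounds than this note shows. Statements on the series, on what has been measured and on what is new or still open speak of the compounds shown alone.

Three related compounds have been tested so far in a functional assay on K562 cells (Homo sapiens) for antiproliferative activity, read by MTT assay, with a stated time of 48 h; on this read-out higher numbers stand for weaker inhibition and lower numbers for stronger inhibition. Compound 1 (`COC(=O)[C@H](CC(C)C)NC(=O)c1ccc(Oc2nc3ccccc3nc2C)cc1`) gives 22600 nM, compound 2 (`COC(=O)[C@H](C)NC(=O)c1ccc(Oc2nc3ccccc3nc2NC(C)(C)C)cc1`) gives 42200 nM, and compound 3 (`CC[C@@H](C)[C@H](NC(=O)c1ccc(Oc2nc3ccccc3nc2NC(C)(C)C)cc1)C(=O)OC`) gives 38700 nM, a number within the scatter of both others.

The next compound, compound 4 (`COC(=O)[C@H](CC(C)C)NC(=O)c1ccc(Oc2nc3ccccc3nc2NC(C)(C)C)cc1`), keeps the atoms of compound 3 but joins them differently: isobutyl in place of sec-butyl on a saturated chain carbon bound to an amide-type nitrogen and a carbonyl carbon. Put simply, this is isobutyl in place of sec-butyl on a saturated chain carbon bound to an amide-type nitrogen and a carbonyl carbon.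

Among the measured compounds shown here, the one measured step at this carbon replaces methyl with sec-butyl, and it is a 1.1-fold lower number from compound 2 to compound 3 (0.04 log units; within the scatter). Compound 1 also carries isobutyl there, but it differs from compound 4 elsewhere on the core, so it offers no clean comparison. For the measured compounds named here, with only that small step as a guide, no change beyond the scatter is expected in this assay. The expected step is a 1.1-fold lower number from compound 3 to compound 4 (0.04 log units; within the scatter). For compound 4 the estimated value is 35000 nM, with an expected range from 19000 nM to 62000 nM.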

Compound 4, half-maximal inhibitory concentration: > 50000 nM
Compound 4: only a limit was reported; the forecaster's own chance of this, stated with the estimate: 10%; middle value at least 1.4-fold (0.15 log units) away from the limit.
By their numbers in this assay, from the lowest: compounds 1, 3 and 2 (each within the scatter of the next). At a limit, above all of these: compound 4.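

Compound 4 gives no number, only a limit of the assay: the limit of > 50000 nM in this assay, at which 1 of the 4 values shown sits. Going by these compounds, at the saturated chain carbon, the change reads as an at least 1.2-fold higher number from compound 3 to compound 4 (0.11 log units; that floor lies within the scatter) and as an at least 1.1-fold higher number from compound 2 to compound 4 (0.07 log units; that floor lies within the scatter) in this assay and both are floors, so isobutyl cannot be told apart from sec-butyl or methyl here, and the true size of either step remains unknown. The new information lies on the core: with isobutyl kept on the chain carbon, (tert-butyl)amino in place of methyl on an aromatic carbon gives an at least 2.2-fold higher number from compound 1 to compound 4 (0.34 log units; beyond the scatter) and this floor already lies beyond the scatter, so this swap goes with weaker inhibition.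

Still open, on these data alone, is how a benzyl group on the chain carbon would read. Also open, as far as these compounds go, is whether a carboxylic acid in place of the methyl ester would shift the number in this assay at all.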